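The source may report more compounds than this note shows. Statements on the series, on what has been measured and on what is new or still open speak of the compounds shown alone.

Working notes on a short series tested in an ADME assay on L02 cells (Homo sapiens) for cytotoxicity, read by MTT assay, with a stated time of 72 h; a lower number here means a stronger inhibitor, a higher number a weaker inhibitor. Compound 1 `COc1ccc(Nc2nc3c(c(Oc4cccc(NC(=O)C=C(C)C)c4)n2)CSCC3)cc1` carries the shared core. In this assay compound 1 gives > 50000 nM, which is a limit of the assay and not a number. Compound 2 `COc1ccc(Nc2nc3c(c(Oc4cccc(NC(=O)/C=C/C(C)C)c4)n2)CSCC3)cc1` differs from compound 1 by 3-methylbut-1-en-1-yl in place of 2-methylprop-1-en-1-yl on a carbonyl carbon. In this assay compound 2 gives > 50000 nM, again a limit. The step that the two limits leave unreadable from compound 1 to compound 2 therefore cannot be sized. Compound 3 `COc1ccc(Nc2nc3c(c(Oc4cccc(NC(=O)C=C(C)C)c4)n2)CSCC3)cn1` differs from compound 1 in the core by 6-methoxypyridin-3-yl in place of 4-methoxyphenyl on a nitrogen on an aromatic ring. In this assay compound 3 gives > 50000 nM, also a limit. The step that the two limits leave unreadable from compound 1 to compound 3 is likewise not readable. All three values sit at the limit of > 50000 nM in this assay, at which 3 of the 3 values shown sit.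

Compound 4 `COc1ccc(Nc2nc3c(c(Oc4cccc(NC(=O)/C=C/C(C)C)c4)n2)CSCC3)cn1` is not yet measured; it differs from compound 3 by 3-methylbut-1-en-1-yl in place of 2-methylprop-1-en-1-yl on a carbonyl carbon, the same change as that from compound 1 to compound 2, made at the same place, on a carbonyl carbon whose other neighbours are an amide-type nitrogen. The earlier instance of this change left compound 2 at > 50000 nM, a limit. Because every measured value sits at the limit of > 50000 nM in this assay, at which 3 of the 3 values shown sit, compound 4 is expected to show no readable step, a step that the limit leaves unreadable from compound 3 to compound 4. Compound 4 is estimated at 60000 nM, expected between 30000 nM and 200000 nM, and most probably reported only as a limit.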

Compound 4, half-maximal inhibitory concentration: > 50000 nM
Compound 4: only a limit was reported; the forecaster's own chance of this, stated with the estimate: 85%; the middle value lies beyond the limit too.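

Compound 4 gives > 50000 nM, a limit of the assay and not a number. No new step can be read, neither from compound 3 to compound 4 nor from compound 2 to compound 4: the limit of > 50000 nM in this assay, at which 4 of the 4 values shown sit.

The compounds shown leave open how far any of the four lies beyond that limit, and whether either change alters cytotoxicity at all.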